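Swapping the aryl group on the triazole nitrogen

A few compounds are considered here, and "the series" means these few. Any claim that something is new, unique, unknown or untested is made for them only; others in the source may bear on it.

Compound 2 `COc1cc2c(Oc3ccc(NC(=O)c4cn(-c5ccccc5C)nn4)cc3F)ccnc2cc1OCCCN1CCN(C)CC1` is recorded in a functional assay on MKN-45 cells (Homo sapiens) for cytotoxicity, read by MTT assay, with a stated time of 72 h (on this read-out lower numbers stand for stronger inhibition and higher numbers for weaker inhibition), as "not determined" (no result reported); its standing cannot be placed on any number. Compound 1 `COc1cc2c(Oc3ccc(NC(=O)c4cn(-c5ccc(F)c(F)c5)nn4)cc3F)ccnc2cc1OCCCN1CCC(C)CC1` carries the same 3,4-difluorophenyl that compound 3 receives but differs elsewhere in the molecule. In this assay compound 1 gives 1290 nM. Compound 3 `COc1cc2c(Oc3ccc(NC(=O)c4cn(-c5ccc(F)c(F)c5)nn4)cc3F)ccnc2cc1OCCCN1CCN(C)CC1` arises from compound 2 by 3,4-difluorophenyl in place of 2-methylphenyl on an aromatic nitrogen. Going by the values given here, with no measured pair for this change, the size of the step cannot be read from the data, and no direction beyond the scatter is claimed. Resting on compound 1 at 1290 nM, compound 3 is expected to give 1300 nM in this assay, within a range from 400 nM to 4000 nM.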

Compound 3, half-maximal inhibitory concentration: 160 nM
The estimate for compound 3 lay 8.1-fold (0.91 log units) above the measured number; the whole stated range lies above it.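

In this assay, with 3,4-difluorophenyl held fixed, 4-methylpiperazin-1-yl in place of 4-methylpiperidin-1-yl brings an 8.1-fold lower number from compound 1 to compound 3 (0.91 log units; beyond the scatter) and so shows that the group at the end of the chain alone moves this number beyond the scatter. Compound 2 has no number, and the step from it to compound 3 cannot be read. Nothing given here accounts for the difference between compound 1 and compound 3. Where a morpholin-4-yl or a dimethylamino group at the end of the same chain would fall remains open, as does how an unsubstituted phenyl or a 4-fluorophenyl on the aromatic nitrogen would compare.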